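The source may report more compounds than this note shows. Statements on the series, on what has been measured and on what is new or still open speak of the compounds shown alone.

- compound 1 `CNc1nc(-c2cc(OC)c(OC)c(OC)c2)c(-c2ccc(C(F)(F)F)cc2)s1`: 4570 nM
- compound 2 `CCOc1ccc(-c2sc(NC)nc2-c2cc(OC)c(OC)c(OC)c2)cc1`: 38.6 nM

In a functional assay on A549 cells (Homo sapiens) for antiproliferative activity, read by MTT assay, with a stated time of 72 h (a higher number here means a weaker inhibitor, a lower number a stronger inhibitor), compound 1 gives 4570 nM, the higher of the two numbers and so the weaker inhibitor of the pair. For the measured compounds named here, the one measured step, a 120-fold lower number from compound 1 to compound 2 (2.07 log units; beyond the scatter), is large and beyond the scatter. It swaps trifluoromethyl for ethoxy on an aromatic carbon.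

Compound 3 `COc1cc(-c2nc(C)sc2-c2ccc(C(F)(F)F)cc2)cc(OC)c1OC` keeps that trifluoromethyl and changes another part of compound 1: methyl in place of methylamino on an aromatic carbon. Here methyl stands in place of methylamino, on an aromatic carbon of a five-membered aromatic ring with 1 nitrogen and 1 sulfur.

Going by the values given here, no measured compound tests a change at this place, so the size of the new step cannot be read from the data. The measured step shows only that a single replacement can move the number a long way in this small set. A moderate move toward a higher number in this assay is therefore expected, with a wide margin, and the expected step is a 2.0-fold higher number from compound 1 to compound 3 (0.29 log units; within the scatter). The estimated value for compound 3 is 9000 nM, with an expected range of 2500 nM to 30000 nM.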

Compound 3, half-maximal inhibitory concentration: 4290 nM
Compound 3: the middle estimate sits 2.1-fold (0.32 log units) above what was measured; the range from low to high includes it.
By their numbers in this assay, from the lowest: compound 2; then compounds 3 and 1 (each within the scatter of the next).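

In this assay, the exchange of methylamino for methyl on this aromatic carbon of the five-membered ring gives a 1.1-fold lower number from compound 1 to compound 3 (0.03 log units; within the scatter) and so stays within the scatter, even though the group that leaves carries 1 hydrogen-bond donor and 1 hydrogen-bond acceptor and the group that enters carries neither. This place therefore behaves quite differently from the trifluoromethyl place, where the single replacement gives a 120-fold lower number from compound 1 to compound 2 (2.07 log units; beyond the scatter) and lies well beyond the scatter; with trifluoromethyl held in place, the nitrogen of methylamino makes no difference that this assay can resolve. The data offer no measured basis for explaining this result..

Whether methyl can stand in for methylamino equally well alongside ethoxy remains open, since compound 2 gives 38.6 nM with methylamino and the exchange is shown only alongside trifluoromethyl. The compounds shown also leave open how this place would respond to a free amine, a longer chain such as propyl, or a carboxylic acid, so the limits of what it accepts cannot yet be drawn from one step.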